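Oxy to amino exchange at compound 2

A few compounds are considered here, and "the series" means these few. Any claim that something is new, unique, unknown or untested is made for them only; others in the source may bear on it.

Values in a functional assay on NCI-H460 cells (Homo sapiens) for antiproliferative activity, read by sulforhodamine B assay, with a stated time of 48 h; on this read-out lower numbers stand for stronger inhibition and higher numbers for weaker inhibition:
- compound 1 `C/C=C(\C)C(=O)O[C@H]1C=CC(=O)O[C@H]1CCC(=O)[C@H](C)O`: 26000 nM
- compound 2 `C/C=C(\C)C(=O)O[C@H]1C=CC(=O)O[C@H]1COC(=O)[C@H](C)O`: 19000 nM

In this assay, among the measured compounds shown here, compound 2 at 19000 nM lies within the scatter of compound 1, its only measured neighbour. Compound 3 `C/C=C(\C)C(=O)O[C@H]1C=CC(=O)O[C@H]1CNC(=O)[C@H](C)O` is unmeasured and carries one change: ((1-hydroxyethyl)carbonyl)amino in place of ((1-hydroxyethyl)carbonyl)oxy on a saturated chain carbon bound to a saturated ring carbon. For the measured compounds named here, the only measured step at this place, a 1.4-fold lower number from compound 1 to compound 2 (0.14 log units; within the scatter), stayed within the scatter. That single step is thin evidence, and no shift beyond the scatter is expected in this assay, in either direction. For compound 3 the estimated value is 22000 nM, with an expected range of 9000 nM to 50000 nM. This estimate means an expected 1.2-fold higher number from compound 2 to compound 3 (0.06 log units; within the scatter).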

Compound 3, half-maximal inhibitory concentration: 27000 nM
The estimate for compound 3 lay 1.2-fold (0.09 log units) below the measured number, and the stated range covers the measured number.
By their numbers in this assay, from the lowest: compounds 2, 1 and 3 (each within the scatter of the next).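

In this assay the ((1-hydroxyethyl)carbonyl)amino group now joins the oxy and methyl forms on a saturated chain carbon bound to a saturated ring carbon. The steps of a 1.4-fold higher number from compound 2 to compound 3 (0.15 log units; within the scatter) and a 1.0-fold higher number from compound 1 to compound 3 (0.02 log units; within the scatter) both remain within the scatter, so the three forms are not separated by this read-out. No available evidence bears on a reason for this result.

On these data alone, it remains open whether a simple amine, a carboxylic acid or a longer chain at this place would give a shift beyond the scatter. The series also leaves open whether an N-methyl amide would do so.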